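Swapping an Alkyne for a Pyridine on a Shared Core

This account rests on a few compounds, and the source may have more. Where it says the series, first, only, none or still open, it means among the compounds named here.

Compound 1 `COc1ccc2c(c1)OC(COc1ccc(CCC(=O)O)c(F)c1)CO2` gives 80% in a functional assay on HEK293 cells for agonist activity at Free fatty acid receptor 1 (Homo sapiens), read by fluorescence and calcium flux, with a stated time of 10 min; on this read-out lower numbers stand for smaller maximal responses and higher numbers for larger maximal responses.
Compound 2 `O=C(O)CCc1ccc(OCC2COc3ccc(Cl)cc3O2)cc1F` gives 50% in this assay.
Compound 3 `CC#CC(CC(=O)O)c1ccc(OCC2COc3ccc(Cl)cc3O2)cc1` gives 104% in this assay.

Of the three measured compounds, compound 3 has the highest maximal response; its nearest neighbour is compound 1, which lies lower beyond the scatter, and compound 2 lies furthest below it. Compound 4 `O=C(O)CC(c1ccncc1)c1ccc(OCC2COc3ccc(Cl)cc3O2)cc1` has not yet been measured. It differs from compound 3 in one place: pyridin-4-yl in place of prop-1-yn-1-yl on a saturated chain carbon bound to an aromatic carbon and a saturated chain carbon.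

Going by the values given here, the only measured step, a number 30 percentage points lower from compound 1 to compound 2 (beyond the scatter), concerns a change on an aromatic carbon of the shared core, not the saturated chain carbon altered here, so no measured step bears directly on the change from compound 3 to compound 4. With no guide from the data, the most defensible expectation is a step within the usual scatter, at most a modest drop, so compound 4 is estimated at 95% with a likely range from 70% to 115%. This expected estimate corresponds to a step of a number 9 percentage points lower from compound 3 to compound 4 (within the scatter).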

Compound 4, largest response reached (Emax), in percent of the reference or control that the assay uses: 62%
The estimate for compound 4 lay 33 percentage points above the measured number; the whole stated range lies above it.
By their numbers in this assay, from the lowest: compound 2; then compound 4; then compound 1; then compound 3.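

This saturated chain carbon, bound to an aromatic carbon and a saturated chain carbon, is now shown to matter for the maximal response: in this assay, pyridin-4-yl in place of prop-1-yn-1-yl gives a large step (a number 42 percentage points lower from compound 3 to compound 4 (beyond the scatter)). Going by these compounds alone, until now, the only step read lay on an aromatic carbon, so this is the first sign that the group on this chain carbon can shift the response beyond the scatter. No measurement here explains why the response falls with this swap.

The swap changes several things at once, from a triple bond to an aromatic ring that holds a nitrogen and one hydrogen-bond acceptor. A phenyl ring or a simple methyl on the same carbon would help to show which of these changes goes with the lower response.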